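A few compounds are considered here, and "the series" means these few. Any claim that something is new, unique, unknown or untested is made for them only; others in the source may bear on it.

Measured in a functional assay on PC-3 cells (Homo sapiens) for inhibition, read by sulforhodamine B assay, with a stated time of 48 h; on this read-out higher numbers stand for weaker inhibition of growth and lower numbers for stronger inhibition of growth:
Compound 1 `CC1(/C=C/c2ccccc2)C=CC(=O)O1`: 86900 nM
Compound 2 `CC1(/C=C/c2ccccc2C(F)(F)F)C=CC(=O)O1`: 17900 nM
Compound 3 `CC1(/C=C/c2ccccc2O)C=CC(=O)O1`: 112000 nM

Compound 1 holds the second highest of the three numbers. It lies within the scatter of compound 3, as the step of a 1.3-fold higher number from compound 1 to compound 3 (0.11 log units; within the scatter) shows, while the step of a 4.9-fold lower number from compound 1 to compound 2 (0.69 log units; beyond the scatter) goes beyond the scatter.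

Compound 4 `CC1(/C=C/c2ccc(O)cc2)C=CC(=O)O1` has not yet been measured. Compared with compound 1, it carries hydroxy in place of hydrogen on an aromatic carbon, para to a group of 9 heavy atoms (hydroxy in place of hydrogen on an aromatic carbon).

Within the data shown here, the closest precedent is compound 3, which has the same hydroxy on another carbon of that ring and gave a 1.3-fold higher number from compound 1 to compound 3 (0.11 log units; within the scatter). The larger steps, a 4.9-fold lower number from compound 1 to compound 2 (0.69 log units; beyond the scatter) and a 6.3-fold higher number from compound 2 to compound 3 (0.80 log units; beyond the scatter), both involve trifluoromethyl and so bear on this change only indirectly. No step beyond the scatter is therefore expected in this assay, and the expected step is a 1.1-fold higher number from compound 1 to compound 4 (0.04 log units; within the scatter). Compound 4 is estimated at 95000 nM, with an expected range from 45000 nM to 190000 nM.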

Compound 4, concentration for total growth inhibition: 138000 nM
Beside the measured number, compound 4's estimate is 1.5-fold (0.16 log units) below it, and the stated range covers the measured number.
By their numbers in this assay, from the lowest: compound 2; then compounds 1, 3 and 4 (each within the scatter of the next).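

In this assay, hydroxy in place of hydrogen on an aromatic carbon, para to a group of 9 heavy atoms, gives a 1.6-fold higher number from compound 1 to compound 4 (0.20 log units; within the scatter). With compound 3, which carries hydroxy on another carbon of that ring, this change has now been read at two carbons of the ring, and at neither does its step from compound 1 go beyond the scatter. Among the compounds shown, only the trifluoromethyl of compound 2 moves the number beyond the scatter from compound 1, and nothing available explains this difference between the groups.

The compounds shown leave open whether trifluoromethyl at this para position would give a step like that of compound 2. They also leave open how a methoxy group, an amine or a carboxylic acid would behave on either carbon.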